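Shrinking the Amine Ring on the Shared Core

The source may report more compounds than this note shows. Statements on the series, on what has been measured and on what is new or still open speak of the compounds shown alone.

Compound 1, `O=C(Nc1ccc(-c2cnc3cc(N4CCN(C5CC5)CC4)ccn23)cc1)c1ccc([N+](=O)[O-])o1`, gives 1920 nM in a functional assay on AGS cells (Homo sapiens) for antiproliferative activity, read by CCK-8 assay, with a stated time of 72 h; on this read-out lower numbers stand for stronger inhibition and higher numbers for weaker inhibition.
Compound 2, `O=C(Nc1ccc(-c2cnc3cc(C4=CCN(C5COC5)CC4)ccn23)cc1)c1ccc([N+](=O)[O-])o1`, gives 790 nM in this assay.
Compound 3, `CC1(O)CCN(c2ccn3c(-c4ccc(NC(=O)c5ccc([N+](=O)[O-])o5)cc4)cnc3c2)CC1`, gives 1530 nM in this assay.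

Among these three, compound 3 holds the second highest number: the nearer of its two steps is a 1.3-fold lower number from compound 1 to compound 3 (0.10 log units; within the scatter), and the further one is a 1.9-fold higher number from compound 2 to compound 3 (0.29 log units; within the scatter). Compound 4, `O=C(Nc1ccc(-c2cnc3cc(N4CCC4)ccn23)cc1)c1ccc([N+](=O)[O-])o1`, carries azetidin-1-yl in place of 4-hydroxy-4-methylpiperidin-1-yl on an aromatic carbon. Going by the values given here, no measured step swaps a ring for a smaller one of this kind; the only step beyond scatter, a 2.4-fold lower number from compound 1 to compound 2 (0.39 log units; beyond the scatter), concerns a different exchange. The two steps touching compound 3 both sit within scatter, so no shift beyond scatter is expected in this assay. The expected step is a 1.0-fold lower number from compound 3 to compound 4 (0.01 log units; within the scatter), giving compound 4 an estimate of 1500 nM, within a range from 600 nM to 4000 nM.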

Compound 4, half-maximal inhibitory concentration: > 5000 nM
Compound 4: only a limit was reported; the forecaster's own chance of this, stated with the estimate: 5%; middle value at least 3.3-fold (0.52 log units) from the limit.
By their numbers in this assay, from the lowest: compounds 2, 3 and 1 (each within the scatter of the next, the first and the last beyond it). At a limit, above all of these: compound 4.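

Compound 4 gives only a limit, not a number: the limit of > 5000 nM in this assay, at which 1 of the 4 values shown sits. This position therefore does not accept every saturated nitrogen ring, since azetidin-1-yl gives an at least 3.2-fold higher number from compound 3 to compound 4 (0.51 log units; beyond the scatter), an at least 2.6-fold higher number from compound 1 to compound 4 (0.41 log units; beyond the scatter) and an at least 6.3-fold higher number from compound 2 to compound 4 (0.80 log units; beyond the scatter). Each of these steps lies beyond the scatter, so the smallest group shown here is the first to separate clearly from all the other compounds.

The compounds shown cannot separate the smaller ring from the loss of the hydroxy and methyl groups of compound 3. A plain piperidine, a pyrrolidine or a 3-hydroxyazetidine at this position would help to tell these apart.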